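A few compounds are considered here, and "the series" means these few. Any claim that something is new, unique, unknown or untested is made for them only; others in the source may bear on it.

Measured so far in a functional assay on P388 cells (Mus musculus) for cytotoxicity; on this read-out lower numbers stand for stronger inhibition and higher numbers for weaker inhibition:
- compound 1, `Cc1cc(-c2c(F)cc3c(=O)ccn(C4CC4)c3c2F)cc(C)n1`: 15000 nM
- compound 2, `Cc1cc(-c2c(F)cc3c(=O)c(Cc4ccc(O)cc4O)cn(C4CC4)c3c2F)cc(C)n1`: 210 nM
- compound 3, `Cc1cc(-c2c(F)cc3c(=O)c(C(=O)O)cn(C4CC4)c3c2F)cc(C)n1`: 29000 nM

Compound 1 stands second highest of the three numbers. Its nearest neighbour is compound 3, with a 1.9-fold higher number from compound 1 to compound 3 (0.29 log units; within the scatter), a step within the scatter; furthest off is compound 2, with a 71-fold lower number from compound 1 to compound 2 (1.85 log units; beyond the scatter).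

The next compound, compound 4 `Cc1cc(-c2c(F)cc3c(=O)c(Cc4c(O)cc(O)cc4O)cn(C4CC4)c3c2F)cc(C)n1`, is not yet measured. Against compound 1 the change is 2,4,6-trihydroxybenzyl in place of hydrogen on an aromatic carbon.

The step that bears on this is the one to the 2,4-dihydroxybenzyl analogue, a 71-fold lower number from compound 1 to compound 2 (1.85 log units; beyond the scatter), a large move to a lower number. The contrast a 140-fold higher number from compound 2 to compound 3 (2.14 log units; beyond the scatter) shows the same carbon carrying a carboxy group instead, which sits far above the dihydroxybenzyl compound. Only compound 2 carries a hydroxybenzyl group, so the data give no reading on what a third hydroxyl adds; the working assumption is that compound 4 tracks compound 2, with a large step down from compound 1 expected: a 50-fold lower number from compound 1 to compound 4 (1.70 log units; beyond the scatter).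

For compound 4 the estimate in this assay is 300 nM, with a range of 60 nM to 1500 nM.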

Compound 4, half-maximal inhibitory concentration: 470 nM
Compound 4: the middle estimate sits 1.6-fold (0.19 log units) below what was measured, and the stated range covers the measured number.
By their numbers in this assay, from the lowest: compound 2; then compound 4; then compounds 1 and 3 (each within the scatter of the next).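

In this assay the large drop on putting a hydroxybenzyl group on this aromatic carbon no longer rests on a single compound: 2,4,6-trihydroxybenzyl in place of hydrogen also gives a large step (a 32-fold lower number from compound 1 to compound 4 (1.50 log units; beyond the scatter)), and it stands far from the carboxy group on the same carbon (a 62-fold lower number from compound 3 to compound 4 (1.79 log units; beyond the scatter)). The added hydroxy on the benzyl ring does shift the number, but only in a modest step beyond the scatter and towards weaker inhibition (a 2.2-fold higher number from compound 2 to compound 4 (0.35 log units; beyond the scatter)), so most of the gain over the unsubstituted position survives with the third hydroxyl in place. No measurement at hand explains either the large gain or the modest loss from the extra hydroxy.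

Still open, as far as these compounds go, is whether the benzyl ring needs its hydroxyls at all, a question that a plain benzyl group or a dimethoxybenzyl group on the same carbon would answer, and whether an aminomethyl group could stand in for the benzyl group. Also open, from the compounds shown here alone, is whether the step holds when the cyclopropyl group on the shared core gives way to an ethyl group.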